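Swapping methoxy for methylcarbamoyl in a bis-sulfonamide series

This account rests on a few compounds, and the source may have more. Where it says the series, first, only, none or still open, it means among the compounds named here.

Measured compounds:
compound 1 `COc1ccc(S(=O)(=O)Nc2ccc(NS(=O)(=O)c3ccc(F)cc3)cc2)cc1`: > 100000 nM
compound 2 `O=S(=O)(Nc1ccc(NS(=O)(=O)c2cc(Cl)ccc2Cl)cc1)c1cc(Cl)ccc1Cl`: > 100000 nM
compound 3 `O=S(=O)(Nc1ccc(NS(=O)(=O)c2ccc(Br)cc2)cc1)c1ccc(Br)cc1`: > 100000 nM

All three measured compounds share the core of compound 1, two aryl sulfonamides joined through a central ring. In an assay for inhibition of liver carboxylesterase 1 (Homo sapiens), read by spectrophotometry (a lower number here means a stronger inhibitor, a higher number a weaker inhibitor), compound 1 gives > 100000 nM, which is a limit of the assay and not a measured number. Compound 2 also reaches only a limit in this assay, > 100000 nM. Compound 3 likewise stops at a limit, > 100000 nM. Going by the values given here, compound 1 therefore cannot be ranked against the other two: every value shown sits at the limit of > 100000 nM in this assay, at which 3 of the 3 values shown sit, and no step between any pair of measured compounds is available.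

Compound 4 `CNC(=O)c1ccc(S(=O)(=O)Nc2ccc(NS(=O)(=O)c3ccc(F)cc3)cc2)cc1` differs from compound 1 in one place: methylcarbamoyl in place of methoxy on an aromatic carbon. Among the compounds with values here, with no measured step to draw on, the size of this change cannot be read from earlier pairs. Because all three measured values rest on (the limit of > 100000 nM in this assay, at which 3 of the 3 values shown sit), the step from compound 1 to compound 4 is expected to be none beyond the scatter, that is a step that the limit leaves unreadable from compound 1 to compound 4, with the assay most likely returning another limit. Compound 4 is accordingly estimated at 150000 nM, within a range from 30000 nM to 1000000 nM.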

Compound 4, inhibition constant: > 100000 nM
Compound 4 was reported as a limit; the forecaster's own chance of this, stated with the estimate: 80%; the middle value lies beyond the limit too.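

Compound 4, like compound 1, stops at a limit and not at a measured number, so no step can be read from one to the other: the limit of > 100000 nM in this assay, at which 4 of the 4 values shown sit. The compounds shown leave open whether methylcarbamoyl in place of methoxy alters inhibition, and whether any compound with the shared core gives a measured number in this assay at all.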